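A few compounds are considered here, and "the series" means these few. Any claim that something is new, unique, unknown or untested is made for them only; others in the source may bear on it.

Measured so far:
compound 1, `COc1cc(OC)c(OC)cc1/C=C/C(=O)c1ccc(O)cc1`: 182000 nM
compound 2, `COc1cc(OC)c(OC)cc1/C=C/C(=O)c1cc(O)ccc1O`: > 150000 nM

Both numbers come from a functional assay on MCF7 cells (Homo sapiens) for inhibition, read by MTT assay, with a stated time of 72 h; on this read-out higher numbers stand for weaker inhibition and lower numbers for stronger inhibition. Compound 1 gives 182000 nM, which is weak inhibition. For compound 2 this assay reports only a limit, > 150000 nM, so compound 2 is placed only by that bound (the limit of > 150000 nM in this assay, at which 1 of the 2 values shown sits). The step that the limit leaves unreadable from compound 1 to compound 2 therefore has no readable size. Compound 3, `COc1cc(OC)c(OC)cc1/C=C/C(=O)c1ccc(Br)cc1`, is not yet measured; it differs from compound 2 by 4-bromophenyl in place of 2,5-dihydroxyphenyl on a carbonyl carbon. Among the compounds with values here, the group that leaves here is the same one whose entry left the step from compound 1 unreadable, so no measured step gives a size for this change, and both measured compounds sit at very weak inhibition. The step of an at least 1.6-fold lower number from compound 2 to compound 3 (0.22 log units; that floor lies within the scatter) is expected to stay within the ordinary scatter, with wide uncertainty in either direction. Compound 3 is estimated at 90000 nM, between 20000 nM and 300000 nM.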

Compound 3, half-maximal inhibitory concentration: 18300 nM
Beside the measured number, compound 3's estimate is 4.9-fold (0.69 log units) above it, outside the stated range (below it).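

In this assay, replacing the group on the carbonyl carbon now moves the number beyond the scatter: 4-bromophenyl in place of 2,5-dihydroxyphenyl gives an at least 8.1-fold lower number from compound 2 to compound 3 (0.91 log units; beyond the scatter), and bromo in place of hydroxy on an aromatic carbon gives a 9.9-fold lower number from compound 1 to compound 3 (1.00 log units; beyond the scatter). Within the data shown here, the second step has an exact size and changes only one group on the ring, while the step between the two earlier compounds cannot be read. The first step gives only a floor, because compound 2 is held by a limit: the limit of > 150000 nM in this assay, at which 1 of the 3 values shown sits.

The compounds shown leave open whether the stronger inhibition is specific to bromo or would also appear with another group in place of the hydroxy, such as chloro, methoxy or an amine. They also leave open how changes to the shared core would act, as all three compounds keep it unchanged.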